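From Ethyl to Butyl: One Chain Extension Examined

The source may report more compounds than this note shows. Statements on the series, on what has been measured and on what is new or still open speak of the compounds shown alone.

compound 1, `Cc1ccc(CC(C)(Oc2ccc(C(C)C)cc2)C(=O)O)cc1`: < 1 mg/kg
compound 2, `CCc1ccc(CC(C)(Oc2ccc(C(C)C)cc2)C(=O)O)cc1`: 0.1 mg/kg

Two measured compounds share one core and differ only at a saturated chain carbon bound to an aromatic carbon. In a functional assay on the whole organism for inhibition, with Rattus norvegicus as the target (on this read-out lower numbers stand for an effect already at smaller amounts and higher numbers for an effect only at larger amounts of compound), compound 1 gives only a limit, < 1 mg/kg, and not a number. In this assay compound 2 gives 0.1 mg/kg, the single number shown, so its standing among the measured compounds rests on that one value. The step that the limit leaves unreadable from compound 1 to compound 2 cannot be read because the limit of < 1 mg/kg in this assay, at which 1 of the 2 values shown sits, hides where compound 1 truly sits.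

Compound 3, `CCCCc1ccc(CC(C)(Oc2ccc(C(C)C)cc2)C(=O)O)cc1`, differs from compound 2 by ethyl in place of hydrogen on a saturated chain carbon, two bonds along the chain from an aromatic carbon. No measured step bears on this change: the only step shown, from methyl to ethyl, is unreadable, so neither its size nor its direction offers guidance for going from ethyl to butyl. The expectation for compound 3 is therefore a step within the scatter, a 1.5-fold higher number from compound 2 to compound 3 (0.18 log units; within the scatter), with no direction favoured. Compound 3 is estimated at 0.15 mg/kg in this assay, between 0.03 mg/kg and 0.7 mg/kg.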

Compound 3, dose for half-maximal effect: 1 mg/kg
Beside the measured number, compound 3's estimate is 6.7-fold (0.82 log units) below it, outside the stated range (above it).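

Going from ethyl to butyl on a saturated chain carbon, two bonds along the chain from an aromatic carbon, gives in this assay a 10-fold higher number from compound 2 to compound 3 (1.00 log units; beyond the scatter). For the compounds shown here, this is the first readable step at this position, and it shows that the position is not indifferent to chain length: adding ethyl, which brings only carbon, no ring and no charge, is enough to make compound 3 need a clearly larger dose than compound 2. The steps that start from compound 1 cannot be read (among them a number no lower from compound 1 to compound 3 (the limit leaves the size open)), so the methyl compound cannot yet be placed on this trend, because it gives only a limit and not a number: the limit of < 1 mg/kg in this assay, at which 1 of the 3 values shown sits.

Going by these compounds alone, with only one readable step, it remains open whether activity falls gradually or suddenly as the chain grows, and a propyl group at this place would speak to that. As far as these compounds go, it is equally open whether a longer chain such as hexyl would continue the trend, and whether a chain ending in an amine or a hydroxyl group would behave like butyl.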